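A few compounds are considered here, and "the series" means these few. Any claim that something is new, unique, unknown or untested is made for them only; others in the source may bear on it.

Measured so far in a functional assay on V79 cells (Cricetulus griseus) for cytotoxicity, read by colony formation; a lower number here means a stronger inhibitor, a higher number a weaker inhibitor:
Compound 1 `NCC1CCN(c2c(F)cc3c(=O)c(C(=O)O)cn(C4CC4)c3c2F)C1` gives 11 ug/mL.
Compound 2 `NCC1CCN(c2c(F)cc3c(=O)c(C(=O)O)cn(C4CC4)c3c2Cl)C1` gives 8 ug/mL.

Compound 2 has the lowest of the two numbers in this assay, but its nearest neighbour is compound 1, and the step of a 1.4-fold lower number from compound 1 to compound 2 (0.14 log units; within the scatter) lies within the scatter, so the two cannot be ranked against each other.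

Compound 3 `NC1CCCN(c2c(F)cc3c(=O)c(C(=O)O)cn(C4CC4)c3c2Cl)C1` differs from compound 2 only in the substituent on the shared core: 3-aminopiperidin-1-yl in place of 3-(aminomethyl)pyrrolidin-1-yl on an aromatic carbon. Among the measured compounds shown here, the one measured step, a 1.4-fold lower number from compound 1 to compound 2 (0.14 log units; within the scatter), concerns a halogen on the aromatic carbon and says nothing about the amine-bearing ring; no measured pair bears on this change. With no guide in the data, the expected step of a 1.1-fold higher number from compound 2 to compound 3 (0.05 log units; within the scatter) is set at none beyond the scatter, with a wide range to cover the unknown. Compound 3 is therefore estimated at 9 ug/mL, between 3 ug/mL and 27 ug/mL.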

Compound 3, half-maximal inhibitory concentration: 24 ug/mL
For compound 3 the middle estimate is 2.7-fold (0.43 log units) below the measured one, within the range that was stated.
By their numbers in this assay, from the lowest: compounds 2 and 1 (each within the scatter of the next); then compound 3.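

Among the compounds shown here, exchanging 3-(aminomethyl)pyrrolidin-1-yl for 3-aminopiperidin-1-yl gives a 3.0-fold higher number from compound 2 to compound 3 (0.48 log units; beyond the scatter) in this assay, the only step in this set beyond the scatter. The position on the aromatic carbon ortho to a chloro group and ortho to a fluoro group thus responds to how the same atoms are joined, which the halogen exchange on the shared core could not show. Nothing measured here accounts for this difference.

In this change the ring size and the attachment of the amine move together, and 3-aminopyrrolidin-1-yl or 3-(aminomethyl)piperidin-1-yl would be needed to tell them apart. On these data alone, it also remains open whether 3-aminopiperidin-1-yl gives a similar step with fluoro in place of chloro on the shared core.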